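The compounds below may be only part of what the source reports. "The series", "measured", "known", "first", "only" and "open" are said of these compounds alone.

Measured so far in a functional assay on NCI-H1975 cells (Homo sapiens) for inhibition, read by sulforhodamine B assay, tested at 10 uM; a higher number here means more inhibition at the concentration tested (going by the name of the read-out), a lower number less inhibition:

compound 1 `CN1CCN(c2ccc(C3=NN(C(=O)/C=C/c4ccccc4)C(c4ccc(N(C)C)cc4)C3)cc2)CC1`, 81%
compound 2 `CN1CCN(c2ccc(C3=NN(S(=O)(=O)c4ccc(Br)cc4)C(c4ccc(N(C)C)cc4)C3)cc2)CC1`, 70.8%

For the measured compounds named here, compound 2 stands lowest of the two numbers; its only neighbour is compound 1, and the step of a number 10.2 percentage points lower from compound 1 to compound 2 (beyond the scatter) is the one measured step. That step exchanges the group on the amine nitrogen in the ring; it does not touch the aromatic substituent that changes next.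

Compound 3 `CN(C)c1ccc(C2CC(c3ccc(-n4cncn4)cc3)=NN2S(=O)(=O)c2ccc(Br)cc2)cc1` differs from compound 2 in one place: 1H-1,2,4-triazol-1-yl in place of 4-methylpiperazin-1-yl on an aromatic carbon. The position is on an aromatic carbon of a six-membered aromatic ring of carbon only, para to a large group. Going by the values given here, no measured step bears on an exchange at this position, and the series gives no reading of what the 1H-1,2,4-triazol-1-yl ring does in this assay . With nothing to lean on, the step from compound 2 to compound 3 is expected to stay within the scatter or be modest, a number 5.8 percentage points lower from compound 2 to compound 3 (within the scatter), with the direction left open.

Compound 3 is therefore expected to give about 65% in this assay , in the range 45% to 85%.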

Compound 3, a percentage reported as inhibition, at one concentration (the size of the read-out at that concentration, not a potency): -0.6%
Beside the measured number, compound 3's estimate is 65.6 percentage points above it; the whole stated range lies above it.
By their numbers in this assay, from the lowest: compound 3; then compound 2; then compound 1.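

In this assay the aromatic carbon para to a large group is where a single exchange counts most so far: 1H-1,2,4-triazol-1-yl in place of 4-methylpiperazin-1-yl gives a number 71.4 percentage points lower from compound 2 to compound 3 (beyond the scatter), against a number 10.2 percentage points lower from compound 1 to compound 2 (beyond the scatter) for the exchange on the ring nitrogen. Compound 2 and compound 3 both carry the (4-bromophenyl)sulfonyl group, so that group alone does not secure inhibition at the concentration tested, and what sits on this aromatic carbon decides between a clear read-out and compound 3 at -0.6%. Nothing at hand explains the size of this drop.

Going by these compounds, the exchange replaces a six-membered non-aromatic ring with a five-membered aromatic one, so it remains open which feature of the change matters; morpholin-4-yl, piperidin-1-yl or 1H-imidazol-1-yl on the same carbon would begin to separate them. On these data alone, it also remains open whether 1H-1,2,4-triazol-1-yl has the same effect when the ring nitrogen carries the (2-phenylethenyl)carbonyl group of compound 1.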